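Removing the ethyl from the ring amine of compound 1

The source may hold more compounds than are shown below. What is called first, only, known or untested is meant among the compounds shown, and "the series" means these compounds.

Compound 1 `CCOCCn1c(N2CCN(CC)CC2)nc2ccccc21` and compound 2 `CCOCCn1c(N2CCCN(Cc3ccccc3)CC2)nc2ccccc21` share one core and differ in the saturated ring and in what sits on its amine nitrogen. In a functional assay on ileum for inhibition of histamine H1 receptor (Cavia porcellus) (a lower number here means a stronger inhibitor, a higher number a weaker inhibitor), compound 1 gives 18 nM. In this assay compound 2 gives 15 nM. For the measured compounds named here, the two numbers lie within the usual scatter of each other, so neither compound can be set apart from the other; compound 1 merely holds the higher of the two numbers so far. Going by the values given here, no measured pair differs in a single place, so no measured step is available to lean on.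

Compound 3 `CCOCCn1c(N2CCNCC2)nc2ccccc21` is the next member and has not yet been measured in this assay. It differs from compound 1 in one place: hydrogen in place of ethyl on an amine nitrogen in a ring. Among the compounds with values here, with no measured step to guide, the expected step of a 3.9-fold higher number from compound 1 to compound 3 (0.59 log units; beyond the scatter) is a moderate move toward a higher number, beyond the scatter, though the uncertainty is wide. For compound 3 the estimate in this assay is 70 nM, with a range from 20 nM to 300 nM.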

Compound 3, half-maximal inhibitory concentration: 11 nM
The estimate for compound 3 lay 6.4-fold (0.80 log units) above the measured number; the whole stated range lies above it.
By their numbers in this assay, from the lowest: compounds 3, 2 and 1 (each within the scatter of the next).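

In this assay, for the compounds shown here, the step of a 1.6-fold lower number from compound 1 to compound 3 (0.21 log units; within the scatter) is the first measured single-place change, and it leaves ethyl and hydrogen on this amine nitrogen in a ring indistinguishable. At this position, therefore, the two carbon atoms of the ethyl are not required for a number of this size, and their loss costs nothing that can be read beyond the scatter. Nothing on hand bears on why the step is this small.

On these data alone, how far this tolerance extends on the same nitrogen remains open, since a single pair of ethyl and hydrogen says nothing about a longer chain such as butyl, an acetyl group or a chain ending in a carboxylic acid, and compound 2 differs from compound 1 and compound 3 in the saturated ring as well as on the amine nitrogen, so it cannot settle the matter. The rest of the molecule is equally untested, as all three compounds carry the same ether chain on the shared core, and a shorter chain or a plain alkyl chain there could behave differently.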